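The source may report more compounds than this note shows. Statements on the series, on what has been measured and on what is new or still open speak of the compounds shown alone.

Measured in a functional assay on HepG2 cells (Homo sapiens) for cytotoxicity, read by MTT assay, with a stated time of 24 h; on this read-out lower numbers stand for stronger inhibition and higher numbers for weaker inhibition:
Compound 1 `CN1C/C(=C\c2ccc(C(C)(C)C)cc2)C(=O)/C(=C/c2ccccc2F)C1`: 9120 nM
Compound 2 `CN1C/C(=C\c2ccc(C#N)cc2)C(=O)/C(=C/c2ccccc2F)C1`: 590 nM

Compound 2 holds the lower of the two numbers, at 590 nM. Going by the values given here, the only measured step is a 15-fold lower number from compound 1 to compound 2 (1.19 log units; beyond the scatter), with cyano in place of tert-butyl on an aromatic carbon. The next compound, compound 3 `CN1C/C(=C\c2ccc(F)cc2)C(=O)/C(=C/c2ccc(C#N)cc2)C1`, has not yet been measured. It carries 4-fluorophenyl in place of 2-fluorophenyl on a double-bonded chain carbon bound to a double-bonded ring carbon.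

Among the compounds with values here, the one measured step bears on this change only indirectly, since its fluorophenyl group stays the same and no measured pair compares 2-fluorophenyl with 4-fluorophenyl. It sets no size for the new change, so no step beyond the scatter is expected in this assay, and the data favour no firm direction. The range is nevertheless kept wide because of a 15-fold lower number from compound 1 to compound 2 (1.19 log units; beyond the scatter). The expected change is a 1.3-fold higher number from compound 2 to compound 3 (0.10 log units; within the scatter). The estimated value for compound 3 is 750 nM, with an expected range of 250 nM to 2200 nM.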

Compound 3, half-maximal inhibitory concentration: 6140 nM
Beside the measured number, compound 3's estimate is 8.2-fold (0.91 log units) below it; measured number above the stated range.
By their numbers in this assay, from the lowest: compound 2; then compounds 3 and 1 (each within the scatter of the next).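

In this assay, going by these compounds alone, 4-fluorophenyl in place of 2-fluorophenyl on a double-bonded chain carbon bound to a double-bonded ring carbon gives a 10-fold higher number from compound 2 to compound 3 (1.02 log units; beyond the scatter) and so shows that the read-out responds strongly to this change, which the earlier compounds had left untested. The earlier step, a 15-fold lower number from compound 1 to compound 2 (1.19 log units; beyond the scatter), concerned cyano in place of tert-butyl and kept 2-fluorophenyl unchanged, whereas the two groups exchanged here have the same heavy atoms, the same aromatic ring, the same donor and acceptor counts and no net charge, so these counts do not separate them even though the numbers differ beyond the scatter. Nothing available accounts for the size of this step.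

The compounds shown leave open whether 3-fluorophenyl, plain phenyl or 2-chlorophenyl at this position would stay near the lower number of compound 2 or the higher number of compound 3. They also leave open whether the same exchange of fluorophenyl groups would give a step of similar size if tert-butyl stood in place of the cyano group.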